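A few compounds are considered here, and "the series" means these few. Any claim that something is new, unique, unknown or untested is made for them only; others in the source may bear on it.

Working notes on the series. Among the compounds with values here, in a functional assay on BXPC-3 cells (Homo sapiens) for inhibition, read by XTT assay, with a stated time of 72 h (a lower number here means a stronger inhibitor, a higher number a weaker inhibitor), compound 1 (`CCCCCCCC/C=C\CCCCCCCCOC[C@@H]1CCCN1`) gives 5300 nM and is the only compound with an exact number so far. Compound 2 (`CCCCCCCC/C=C\CCCCCCCCOC[C@@H]1CCCN1C(=O)[C@@H]1CCCN1C(=O)OC(C)(C)C`) gives > 100000 nM as a limit of the assay and not a number. Compound 2 therefore has no exact place on the scale.

Compound 3 (`CCCCCCCC/C=C\CCCCCCCCOC[C@@H]1CCCN1C(=O)[C@@H]1CCCN1`) comes from compound 2 by a single change (hydrogen in place of tert-butoxycarbonyl on an amine nitrogen in a ring) with hydrogen in place of tert-butoxycarbonyl on an amine nitrogen in a ring. Within the data shown here, no measured pair isolates this change, so any expectation for it is indirect. Among the measured compounds shown here, compound 1 with 5300 nM also carries hydrogen on its amine nitrogen in a ring, and this is the sole basis for expecting compound 3 to fall in a similar region of this assay. The expected step of an at least 11-fold lower number from compound 2 to compound 3 (1.04 log units; beyond the scatter) is large and beyond the scatter, running toward a lower number and so a stronger inhibitor. Compound 3 is estimated at 9000 nM with an expected range of 3000 nM to 30000 nM for the coming measurement.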

Compound 3, half-maximal inhibitory concentration: 4300 nM
For compound 3 the middle estimate is 2.1-fold (0.32 log units) above the measured one; the range from low to high includes it.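

In this assay, taking tert-butoxycarbonyl off the amine nitrogen in the ring gives a step of an at least 23-fold lower number from compound 2 to compound 3 (1.36 log units; beyond the scatter), so this position responds strongly to this change. Compound 2 is a limit of the assay and not a number, so this step has a floor but no exact size: the limit of > 100000 nM in this assay, at which 1 of the 3 values shown sits. The other step, a 1.2-fold lower number from compound 1 to compound 3 (0.09 log units; within the scatter), lies within the scatter, so (pyrrolidin-2-yl)carbonyl in place of hydrogen on the amine nitrogen in a ring leaves the number where it was, and the loss seen in compound 2 goes with tert-butoxycarbonyl on the added ring and not with the added (pyrrolidin-2-yl)carbonyl unit itself.

The compounds shown leave open whether a smaller group on that amine nitrogen, such as acetyl or methyl, stays in the region of compound 3 or moves toward the limit seen for compound 2. They also leave open how much of the number depends on the long unsaturated chain, since all three compounds carry the same chain and a shorter or saturated chain would be needed to separate its part from that of the amine end.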